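The source may hold more compounds than are shown below. What is called first, only, known or untested is meant among the compounds shown, and "the series" means these compounds.

Working notes on the series. Of the compounds shown here, three have been measured in a functional assay on NCI-H226 cells (Homo sapiens) for inhibition, read by MTT assay, with a stated time of 48 h, tested at 10 uM; a lower number here means less inhibition, a higher number more inhibition at the concentration tested (going by the name of the read-out). Compound 1 `Cc1ccc(Nc2cc(NC(=O)Nc3c(Cl)cccc3Cl)ncn2)cc1F` gives 40.7% in this assay, and compound 2 `COc1ccc(F)cc1Nc1cc(NC(=O)Nc2c(Cl)cccc2Cl)ncn1` gives 31.3% in this assay. The two differ in one place, (5-fluoro-2-methoxyphenyl in place of 3-fluoro-4-methylphenyl on a nitrogen on an aromatic ring), and the step in this assay is a number 9.4 percentage points lower from compound 1 to compound 2 (within the scatter), which is within the scatter, so no change is read from it.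

Compound 3 `COc1cc(NC(=O)Nc2cc(Nc3ccc(C)c(F)c3)ncn2)cc(OC)c1` is built on a different core, and in this assay compound 3 gives 39.7%. The difference between the core of compound 3 and the core of compound 1 is not broken down here. The values of compound 3 and compound 1 lie within the scatter of each other, as do those of compound 3 and compound 2, so no order among the three is claimed.

Compound 4 `COc1cc(NC(=O)Nc2cc(Nc3cc(F)ccc3OC)ncn2)cc(OC)c1` is not yet measured in this assay. It stands to compound 3 as compound 2 stands to compound 1: 5-fluoro-2-methoxyphenyl in place of 3-fluoro-4-methylphenyl on a nitrogen on an aromatic ring. The place is the same in both pairs, so this is the same change, seen twice among the compounds shown, with one measured instance.

For the measured compounds named here, for compound 4 a step of about the same size is expected, a number 9.7 percentage points lower from compound 3 to compound 4 (within the scatter), because the one measured instance of this change gave a number 9.4 percentage points lower from compound 1 to compound 2 (within the scatter) and nothing else speaks for a different outcome on the core of compound 3. In this assay compound 4 is expected to give about 30%, with a likely range from 18% to 42%.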

Compound 4, a percentage reported as inhibition, at one concentration (the size of the read-out at that concentration, not a potency): 37.7%
Compound 4: middle estimate off by 7.7 percentage points, on the low side; the range from low to high includes it.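

The change from 3-fluoro-4-methylphenyl to 5-fluoro-2-methoxyphenyl has now been seen on two cores in this assay, with the new step being a number 2 percentage points lower from compound 3 to compound 4 (within the scatter), and the two instances compare as follows: the same change on two cores in this assay, a number 9.4 percentage points lower (within the scatter) from compound 1 to compound 2 and a number 2 percentage points lower (within the scatter) from compound 3 to compound 4, 7.4 percentage points apart, within the scatter of two such steps

For the compounds shown here, the two steps therefore do not differ, and nothing here speaks against the change behaving alike on the core of compound 1 and the core of compound 3, but each step is itself within the scatter, so this shows only that no change is read on either core, not that a real effect carries over or that the change is neutral on other cores. The other difference, 3,5-dimethoxyphenyl in place of 2,6-dichlorophenyl on an amide-type nitrogen, gives a number 6.4 percentage points higher from compound 2 to compound 4 (within the scatter), so no change is read from that swap either.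

All four compounds carry a fluorinated phenyl group on the nitrogen on the aromatic ring, which leaves open whether an aliphatic amine, a carboxylic acid or a longer chain in that place would give a step beyond the scatter. As far as these compounds go, with readings at a single concentration, the potency of the four compounds also remains open.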